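A dibromophenyl analogue of compound 1

The source may hold more compounds than are shown below. What is called first, only, known or untested is meant among the compounds shown, and "the series" means these compounds.

Measured compounds
Compound 1 `Cc1cc(C)c(-c2nc(CN3CCC(C(=O)NCCCN4C[C@H](C)C[C@H](C)C4)CC3)c(C)o2)c(C)c1`: > 0.5 h (a limit)
Compound 2 `CC[C@@H]1C[C@H](CC)CN(CCCNC(=O)C2CCN(Cc3nc(-c4c(F)cccc4F)oc3C)CC2)C1`: 0.065 h

In an ADME assay on microsomes from liver (Rattus norvegicus) for metabolic stability, read by LC-MS, using NADPH, at 37 degrees C (a higher number here means that the compound lasts longer, a lower number that the compound disappears faster), compound 1 gives > 0.5 h as its reading, which is a limit and not a number. This places compound 1 at the limit of > 0.5 h in this assay, at which 1 of the 2 values shown sits, and leaves its true half-life open. Going by the values given here, compound 2 gives 0.065 h as the only true number so far, and no change in a single place connects it with compound 1.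

Compound 3 `Cc1oc(-c2c(Br)cccc2Br)nc1CN1CCC(C(=O)NCCCN2C[C@H](C)C[C@H](C)C2)CC1` differs from compound 1 in one place: 2,6-dibromophenyl in place of 2,4,6-trimethylphenyl on an aromatic carbon; in words, 2,6-dibromophenyl stands in place of 2,4,6-trimethylphenyl on an aromatic carbon. Among the compounds with values here, no measured step shows what such a swap does in this assay, so any expectation here is a judgement. Within the data shown here, with compound 2 at 0.065 h as the only true number, the expectation leans towards a shorter half-life. A reading of compound 3 at the same limit as compound 1 remains possible. The expected change is an at least 1.6-fold lower number from compound 1 to compound 3 (0.22 log units; that floor lies within the scatter) in that direction. The estimated half-life of compound 3 is 0.3 h with a range from 0.1 h to 0.9 h in this estimate.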

Compound 3, half-life: 0.035 h
Compound 3: middle estimate off by 8.6-fold (0.93 log units), on the high side; the measured number lies below the stated range.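

Going by these compounds alone, with 2,6-dibromophenyl in place of 2,4,6-trimethylphenyl on an aromatic carbon, this assay gives an at least 14-fold lower number from compound 1 to compound 3 (1.15 log units; beyond the scatter), the first step between two measured compounds that differ in one place, and it lies beyond the scatter. It shows that the half-life is not indifferent to the group at this position, and compound 3 gives a true number here, 0.035 h. Compound 1 stands at a limit and not at a number, so the printed step is only a floor on the size of this change: the limit of > 0.5 h in this assay, at which 1 of the 3 values shown sits.

The compounds shown leave open which part of the swap carries the drop, as the two bromine atoms enter and the three methyl groups leave in one and the same step. Whether the drop follows the bromine atoms themselves remains untested among these compounds, and a 2,6-dichlorophenyl or a 2,6-dimethylphenyl group at this place on the core of compound 1 would separate these two parts of the change.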